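The source may hold more compounds than are shown below. What is called first, only, known or untested is meant among the compounds shown, and "the series" means these compounds.

Measured compounds:
- compound 1 `Cc1nc(NC(C2CC2)C2CC2)c2nc(C)n(-c3ccc(OC(F)F)cc3)c2n1`: 31%
- compound 2 `Cc1nc(NC(C2CC2)C2CC2)c2nc(C)n(-c3ccc(OC(F)F)cc3Cl)c2n1`: 86%

In a functional assay on CHO cells for antagonist activity at corticotropin-releasing factor receptor 1 (Homo sapiens), using Schild analysis (on this read-out lower numbers stand for smaller maximal responses and higher numbers for larger maximal responses), compound 2 stands highest of the two numbers, compound 1 being the nearest. For the measured compounds named here, the one measured step, a number 55 percentage points higher from compound 1 to compound 2 (beyond the scatter), is a chloro in place of hydrogen on an aromatic carbon. Compound 3 `COc1cc(OC(F)F)ccc1-n1c(C)nc2c(NC(C3CC3)C3CC3)nc(C)nc21` differs from compound 2 by methoxy in place of chloro on an aromatic carbon. Going by the values given here, no measured step swaps one substituent for another at this carbon, so the step to compound 3 is poorly constrained; the only step shows that occupying this carbon at all matters greatly. Compound 3 is expected to keep most of the gain, with a step of a number 14 percentage points lower from compound 2 to compound 3 (beyond the scatter) estimated. Compound 3 is estimated at 72%, range 40% to 95%.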

Compound 3, largest response reached (reported as Imax), in percent of the reference or control that the assay uses: 79%
Beside the measured number, compound 3's estimate is 7 percentage points below it; the range from low to high includes it.
By their numbers in this assay, from the lowest: compound 1; then compounds 3 and 2 (each within the scatter of the next).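

In this assay the change of chloro to methoxy at this carbon gives a number 7 percentage points lower from compound 2 to compound 3 (within the scatter) and the change of hydrogen to methoxy gives a number 48 percentage points higher from compound 1 to compound 3 (beyond the scatter), so the gain seen with chloro is not confined to that one substituent. Two substituents that differ in heavy atoms and hydrogen-bond acceptors are not separated here, while both stand clear of hydrogen. Nothing available bears on why this holds.

Open, from the compounds shown here alone, is whether an amine, a carboxylic acid or a longer chain such as ethoxy at this carbon would fit the same picture. Also open, going by these compounds, is whether the gain carries over to analogues without the difluoromethoxy group.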